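A Second Methyl on the Sulfonyl Ring of Compound 3

This account rests on a few compounds, and the source may have more. Where it says the series, first, only, none or still open, it means among the compounds named here.

Compound 1 `O=C(/C=C/c1cccc(NS(=O)(=O)c2cccc(Cl)c2)c1)c1nc2ccccc2[nH]1` gives 4160 nM in a functional assay on MCF7 cells (Homo sapiens) for antiproliferative activity, read by MTT assay, with a stated time of 48 h; a higher number here means a weaker inhibitor, a lower number a stronger inhibitor.
Compound 2 `Cc1cccc(S(=O)(=O)Nc2cccc(/C=C/C(=O)c3nc4ccccc4[nH]3)c2)c1` gives 886 nM in this assay.
Compound 3 `Cc1ccc(S(=O)(=O)Nc2cccc(/C=C/C(=O)c3nc4ccccc4[nH]3)c2)cc1` gives 3220 nM in this assay.

Compound 3 stands second highest of the three numbers. Its nearest neighbour is compound 1, a gap within the scatter; compound 2 sits further off, at a number beyond the scatter.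

Compound 4 `Cc1ccc(S(=O)(=O)Nc2cccc(/C=C/C(=O)c3nc4ccccc4[nH]3)c2)cc1C` differs from compound 3 by methyl in place of hydrogen on an aromatic carbon. The change reads 4-methylphenyl to 3,4-dimethylphenyl, so the new methyl sits ortho to a methyl group and meta to a large group on the ring attached to the sulfonyl sulfur.

Within the data shown here, two measured steps bear on this. The step of a 3.6-fold higher number from compound 2 to compound 3 (0.56 log units; beyond the scatter) shows that a methyl in the 3-position of that ring went with a lower number than a methyl in the 4-position. The step of a 4.7-fold lower number from compound 1 to compound 2 (0.67 log units; beyond the scatter) shows that a methyl in the 3-position also went with a lower number than a chloro in the same place. Among the measured compounds shown here, compound 4 keeps the 4-methyl of compound 3 and adds the 3-methyl of compound 2, so a modest drop in this assay is expected, though no measured step tests both methyls together.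

Compound 4 is therefore estimated at 1500 nM, between 500 nM and 5000 nM, an expected step of a 2.1-fold lower number from compound 3 to compound 4 (0.33 log units; beyond the scatter).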

Compound 4, half-maximal inhibitory concentration: 5860 nM
For compound 4 the middle estimate is 3.9-fold (0.59 log units) below the measured one, and the stated range ends below it.
By their numbers in this assay, from the lowest: compound 2; then compounds 3, 1 and 4 (each within the scatter of the next).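

In this assay, putting a methyl on this aromatic carbon of the 4-methylphenyl group gives a 1.8-fold higher number from compound 3 to compound 4 (0.26 log units; within the scatter), so the added methyl leaves no change that can be told from the scatter. The 3,4-dimethylphenyl group also does not share the low number of the single-methyl ring in compound 2, as shown by a 6.6-fold higher number from compound 2 to compound 4 (0.82 log units; beyond the scatter), so the low number of compound 2 does not carry over once both methyl groups are present. The comparison with the chloro-bearing ring gives a 1.4-fold higher number from compound 1 to compound 4 (0.15 log units; within the scatter), which leaves compounds 1, 3 and 4 close together, with compound 2 alone clearly the strongest of the four.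

On these data alone, what an amine, a methoxy group or a carboxylic acid would do at this place on the ring remains open, as does whether any group here could bring the number down to that of compound 2. Why the two methyl groups together fail to match compound 2 also stays open, since nothing shown here speaks to it.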